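The source may hold more compounds than are shown below. What is called first, only, known or untested is meant among the compounds shown, and "the series" means these compounds.

Two compounds of one series have been run in an in vitro functional assay on 1321-N1 cells for agonist activity at P2Y purinoceptor 4 (Homo sapiens), read by scintillation proximity assay and inositol phosphate accumulation (on this read-out lower numbers stand for an effect already at smaller amounts and higher numbers for an effect only at larger amounts of compound), and a third awaits its turn. Compound 1 `O=c1[nH]c(=S)ccn1[C@@H]1O[C@H](COP(=O)(O)O)[C@@H](O)[C@H]1O` is reported in this assay only as the limit > 100000 nM, which is a boundary of the assay rather than a number. Going by the values given here, compound 2 `CCSc1nc(=O)ccn1[C@@H]1O[C@H](COP(=O)(O)O)[C@@H](O)[C@H]1O` gives 4330 nM in this assay, and it stands alone as the only genuine number in the set. Compound 1 is the one that sits at the limit of > 100000 nM in this assay, at which 1 of the 2 values shown sits. Compound 3 `Nc1nc(=O)ccn1[C@@H]1O[C@H](COP(=O)(O)O)[C@@H](O)[C@H]1O` takes the next step from compound 2: amino in place of ethylsulfanyl on an aromatic carbon. Among the compounds with values here, no measured pair in the set shows such an exchange, so the size of the step can only be anticipated. Compound 3 is expected to lose activity relative to compound 2, with a step of a 6.9-fold higher number from compound 2 to compound 3 (0.84 log units; beyond the scatter) that reaches beyond the ordinary scatter, and there is a fair chance that this assay will report only a limit for it. The estimate for compound 3 in this assay is 30000 nM, within a range from 5000 nM to 300000 nM.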

Compound 3, half-maximal effective concentration: 4980 nM
Beside the measured number, compound 3's estimate is 6.0-fold (0.78 log units) above it; the measured number lies below the stated range.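

Amino in place of ethylsulfanyl, on an aromatic carbon between two ring nitrogen atoms, gives a 1.2-fold higher number from compound 2 to compound 3 (0.06 log units; within the scatter) in this assay, so the two compounds cannot be told apart on this read-out. Going by these compounds alone, this is the first reading at this position, and it shows that the position accepts either group without a difference that can be read, although amino has fewer heavy atoms than ethylsulfanyl and carries a hydrogen-bond donor that ethylsulfanyl lacks. Nothing shown here bears on why the exchange leaves the read-out within the scatter.

From the compounds shown here alone, it remains open whether this holds for other groups on the same carbon, such as a methylamino, a methoxy or a longer chain like butylsulfanyl, or whether only some of them would match compound 2 and compound 3 in this assay. Compound 1 differs from both of them in more than one place, and its entry is a limit rather than a number, which leaves it outside any reading of this position: the limit of > 100000 nM in this assay, at which 1 of the 3 values shown sits.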